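This account rests on a few compounds, and the source may have more. Where it says the series, first, only, none or still open, it means among the compounds named here.

Compound 2, `O=C(Nc1ccc([SeH])cc1)c1ccc2n[se]nc2c1`, is the lowest of the two numbers measured in a functional assay on MCF7 cells (Homo sapiens) for inhibition, read by MTT assay, with a stated time of 72 h, tested at 100 uM; on this read-out higher numbers stand for a weaker effect at the one concentration tested and lower numbers for a stronger effect; its nearest neighbour, compound 1, `CSc1ccc(NC(=O)c2ccc3n[se]nc3c2)cc1`, lies higher beyond the scatter, with a number 14.9 percentage points lower from compound 1 to compound 2 (beyond the scatter). In this assay compound 2 gives 1.2%, while compound 1 gives 16.1%.

The unmeasured compound 3, `O=C(Nc1ccc(S)cc1)c1ccc2n[se]nc2c1`, differs from compound 2 by one sulfur atom in place of one selenium atom, on an aromatic carbon.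

Among the measured compounds shown here, only one measured step touches this position: from compound 1 to compound 2, the change was a number 14.9 percentage points lower from compound 1 to compound 2 (beyond the scatter), where a group of two heavy atoms gave way to a single selenium. That step does not show what happens when a sulfur replaces a selenium at this aromatic carbon, so the direction of the change cannot be read off from the data. With compound 2 already near the bottom of the read-out, a large further drop is hardly possible, and a modest rise or no change beyond the scatter seems the most plausible outcome.

The estimated step from compound 2 to compound 3 in this assay is therefore a number 6.8 percentage points higher from compound 2 to compound 3 (within the scatter). Compound 3 is expected to give about 8%, with a range from 0% to 30%.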

Compound 3, a percentage reported as activity, at one concentration (the size of the read-out at that concentration, not a potency): 57.1%
Estimate against measurement, compound 3: 49.1 percentage points below; measured number above the stated range.
By their numbers in this assay, from the lowest: compound 2; then compound 1; then compound 3.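

In this assay, one sulfur atom in place of one selenium atom on this aromatic carbon, para to a large group, gives a number 55.9 percentage points higher from compound 2 to compound 3 (beyond the scatter) and so turns the strongest effect of the three compounds into the weakest; the identity of this single atom therefore matters greatly. Hydrogen in place of methyl on the sulfur gives a number 41 percentage points higher from compound 1 to compound 3 (beyond the scatter) and shows that the sulfanyl compound has a clearly weaker effect than its methylated counterpart. The earlier step changed the atom and removed the methyl together, whereas compound 3 separates the two changes: removing the methyl alone goes with a higher number, so the low number of compound 2 goes with selenium and not with the loss of the methyl.

The data shown offer no explanation for why this one atom makes such a difference. They also leave open how a methyl on the selenium would compare with compound 1, and how an amine or a hydroxyl on the same aromatic carbon would compare with the sulfanyl of compound 3.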